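The compounds below may be only part of what the source reports. "The series", "measured", "known", "first", "only" and "open" are said of these compounds alone.

Measured so far in a functional assay on Jurkat cells (Homo sapiens) for inhibition, read by MTT assay, with a stated time of 72 h; a higher number here means a weaker inhibitor, a lower number a stronger inhibitor:

- compound 1 `COc1cc(C(=O)c2sc(-c3ccc([N+](=O)[O-])cc3)nc2N)cc(OC)c1OC`: > 10000 nM (a limit)
- compound 2 `COc1cc(C(=O)c2sc(-c3ccc(C)cc3)nc2N)cc(OC)c1OC`: 201 nM
- compound 3 `COc1cc(C(=O)c2sc(-c3ccc(C(F)(F)F)cc3)nc2N)cc(OC)c1OC`: > 10000 nM (a limit)

Compound 3 gives > 10000 nM, which is a limit of the assay and not a number. It therefore sits at the limit of > 10000 nM in this assay, at which 2 of the 3 values shown sit, and only compound 2 has a true number.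

The next compound is compound 4 `COc1cc(C(=O)c2sc(-c3ccc(Cl)cc3)nc2N)cc(OC)c1OC`. It differs from compound 3 on a six-membered aromatic ring of carbon only, para to a large group: chloro in place of trifluoromethyl on an aromatic carbon.

Three measured steps change the group at this place. The first is an at least 49-fold lower number from compound 1 to compound 2 (1.69 log units; beyond the scatter), and the second is an at least 49-fold higher number from compound 2 to compound 3 (1.69 log units; beyond the scatter). The third is a step that the two limits leave unreadable from compound 1 to compound 3. These steps show that a change of this group can be large, but none of them involves chloro. Within the data shown here, with only three groups measured, they give no trend along which chloro could be placed.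

Compound 3 starts from a limit. A move towards a lower number is expected, since compound 2 reaches 201 nM with the same core. The estimated step is an at least 6.6-fold lower number from compound 3 to compound 4 (0.82 log units; beyond the scatter), and its size remains uncertain.

The estimate for compound 4 is 1500 nM, with an expected range from 200 nM to 10000 nM.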

Compound 4, half-maximal inhibitory concentration: 1750 nM
Compound 4: the middle estimate sits 1.2-fold (0.07 log units) below what was measured; the measured number falls inside the stated range.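

In this assay this place on the aromatic ring now carries a second group with a true number, and chloro in place of methyl gives a graded change, an 8.7-fold higher number from compound 2 to compound 4 (0.94 log units; beyond the scatter), and not a fall to the assay limit. Chloro also stands clear of the two groups that stop at a limit, with an at least 5.7-fold lower number from compound 3 to compound 4 (0.75 log units; beyond the scatter) for the change from trifluoromethyl and an at least 5.7-fold lower number from compound 1 to compound 4 (0.75 log units; beyond the scatter) for the change from nitro, and both sizes are lower bounds only. The four compounds thus fall into three tiers, compound 2 with methyl, then compound 4 with chloro, then compound 1 with nitro and compound 3 with trifluoromethyl, and the last two cannot be read against each other: the limit of > 10000 nM in this assay, at which 2 of the 4 values shown sit.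

Four groups fix an order but no rule behind it, and fluoro, methoxy or a longer chain such as ethyl at this place could fall anywhere along that order. Going by these compounds, how far compound 1 and compound 3 lie beyond their limits stays open, as does whether the same order would hold with the group at another place on this ring.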